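The source may report more compounds than this note shows. Statements on the series, on what has been measured and on what is new or still open speak of the compounds shown alone.

Of the compounds shown here, two sharing a core have been measured in a functional assay on SW-620 cells (Homo sapiens) for cytotoxicity, read by MTT assay, with a stated time of 72 h; on this read-out lower numbers stand for stronger inhibition and higher numbers for weaker inhibition. In it, compound 1 (`COc1cccc(/C=C2\CCC/C(=C\c3cccc(Br)c3)C2=O)c1OC`) gives 8800 nM and compound 2 (`COc1ccc(/C=C2\CCC/C(=C\c3ccccc3Br)C2=O)cc1OC`) gives 5300 nM. These two numbers lie within the usual scatter of repeated measurements, so compound 2 stands level with compound 1 and the pair cannot be ranked. Compound 3 (`COc1ccc(/C=C2\CCC/C(=C\c3cccc(Cl)c3Cl)C2=O)cc1OC`) carries 2,3-dichlorophenyl in place of the 2-bromophenyl of compound 2, on a double-bonded chain carbon bound to a double-bonded ring carbon: 2,3-dichlorophenyl in place of 2-bromophenyl on a double-bonded chain carbon bound to a double-bonded ring carbon. Among the compounds with values here, no measured pair shows a change of this kind, so the only guide is how closely compound 1 at 8800 nM and compound 2 at 5300 nM agree. The expected result in this assay is no step beyond the scatter, estimated as a 1.1-fold lower number from compound 2 to compound 3 (0.03 log units; within the scatter). The estimate for compound 3 is 5000 nM, with an expected range from 2000 nM to 12000 nM.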

Compound 3, half-maximal inhibitory concentration: 10800 nM
Compound 3: middle estimate off by 2.2-fold (0.33 log units), on the low side; measured number inside the range.
By their numbers in this assay, from the lowest: compounds 2, 1 and 3 (each within the scatter of the next, the first and the last beyond it).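

In this assay, the swap of 2-bromophenyl for 2,3-dichlorophenyl on a double-bonded chain carbon bound to a double-bonded ring carbon gives a 2.0-fold higher number from compound 2 to compound 3 (0.31 log units; beyond the scatter), the first step measured at a single place on the shared core. The number at this position can therefore move when the group it carries changes, although the step is modest and only just clears the usual scatter. The change replaces one bromine with two chlorine atoms at once, and no measurement shown gives a reason for the step.

From the compounds shown here alone, it remains open whether a phenyl carrying a single chlorine, or no halogen at all, would read closer to compound 2 or compound 3. Going by these compounds, the effect of an amine or a carboxylic acid on this phenyl also remains unknown.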